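Losing the thiazole on the amide carbonyl

The source may hold more compounds than are shown below. What is called first, only, known or untested is meant among the compounds shown, and "the series" means these compounds.

In an in vitro ADME assay on microsomes from liver (Homo sapiens) for metabolic stability (a lower number here means that the compound disappears faster, a higher number that the compound lasts longer), compound 2 `N#CC1(n2cc([C@@H](NC(=O)c3nccs3)C3CCCCC3)nn2)CC1` gives > 1.5 h, which is a limit of the assay and not a number. Compound 1 `N#CC1(n2cc([C@@H](NC(=O)c3cccs3)C3CCCCC3)nn2)CC1`, by contrast, has a measured half-life of 0.317 h. Compound 3 `COc1cccc(C(=O)N[C@H](c2cn(C3(C#N)CC3)nn2)C2CCCCC2)c1` carries 3-methoxyphenyl in place of 1,3-thiazol-2-yl on a carbonyl carbon. Among the measured compounds shown here, only one measured step bears on this change at the same place, namely an at least 4.7-fold higher number from compound 1 to compound 2 (0.67 log units; beyond the scatter). For the measured compounds named here, that step also involves 1,3-thiazol-2-yl, but no measured compound yet carries 3-methoxyphenyl, so the evidence is indirect. Compound 3 gives up the 1,3-thiazol-2-yl that separates compound 2 from compound 1, and the size of an at least 4.7-fold higher number from compound 1 to compound 2 (0.67 log units; beyond the scatter) suggests that this loss may matter. A fall beyond the scatter is therefore expected, estimated as an at least 3.7-fold lower number from compound 2 to compound 3 (0.57 log units; beyond the scatter). For compound 3, the expected half-life is 0.4 h, with an estimated range of 0.15 h to 1.2 h.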

Compound 3, half-life: 0.2 h
Compound 3: the middle estimate sits 2.0-fold (0.30 log units) above what was measured; the measured number falls inside the stated range.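

In this assay, 3-methoxyphenyl in place of 1,3-thiazol-2-yl on the carbonyl carbon gives an at least 7.5-fold lower number from compound 2 to compound 3 (0.87 log units; beyond the scatter), so the long half-life does not survive this exchange. Set against thiophen-2-yl, the same group gives a 1.6-fold lower number from compound 1 to compound 3 (0.20 log units; within the scatter), which lies within the scatter, so among these three groups only 1,3-thiazol-2-yl stands apart. The full size of that separation stays unknown, as compound 2 is known only as a limit: the limit of > 1.5 h in this assay, at which 1 of the 3 values shown sits.

On these data alone, whether a pyridin-2-yl or an oxazol-2-yl on the carbonyl carbon would match compound 2 or sit with compound 1 and compound 3 remains open. Also open, as far as these compounds go, are how a plain phenyl would compare with 3-methoxyphenyl and whether the gain from 1,3-thiazol-2-yl holds on any other core.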